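Benzylamine aryl swap: expectation for compound 3

The source may hold more compounds than are shown below. What is called first, only, known or untested is meant among the compounds shown, and "the series" means these compounds.

In an assay on COS-7 cells for inhibition of sodium/nucleoside cotransporter 2 (Homo sapiens), read by scintillation counting, in the presence of a further agent that is not named here (on this read-out higher numbers stand for weaker inhibition and lower numbers for stronger inhibition), compound 2 `Nc1ncnc2c1nc(NCc1ccc3ccccc3c1)n2[C@@H]1O[C@H](CO)[C@@H](O)[C@H]1O` gives 5300 nM, and compound 1 `Nc1ncnc2c1nc(NCc1ccccc1Cl)n2[C@@H]1O[C@H](CO)[C@@H](O)[C@H]1O` gives 5700 nM; the two values lie within the scatter of each other, so neither stands apart. Compound 3 `COc1cccc(CNc2nc3c(N)ncnc3n2[C@@H]2O[C@H](CO)[C@@H](O)[C@H]2O)c1` differs from compound 2 by 3-methoxyphenyl in place of naphthalen-2-yl on a saturated chain carbon bound to a nitrogen on an aromatic ring. Among the compounds with values here, the one measured step that bears on this position is a 1.1-fold lower number from compound 1 to compound 2 (0.03 log units; within the scatter), which changed nothing beyond the scatter. Compound 3 is therefore expected to show no step beyond the scatter in this assay, the expected change being a 1.0-fold higher number from compound 2 to compound 3 (0.02 log units; within the scatter). The estimate for compound 3 is 5500 nM, with a range from 2500 nM to 12000 nM.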

Compound 3, half-maximal inhibitory concentration: 13000 nM
Estimate against measurement, compound 3: 2.4-fold (0.37 log units) below; measured number outside the range, above it.
By their numbers in this assay, from the lowest: compounds 2 and 1 (each within the scatter of the next); then compound 3.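

The position is not indifferent to the aryl group in this assay: 3-methoxyphenyl in place of naphthalen-2-yl gives a modest rise (a 2.5-fold higher number from compound 2 to compound 3 (0.39 log units; beyond the scatter)), and in place of 2-chlorophenyl a similar one (a 2.3-fold higher number from compound 1 to compound 3 (0.36 log units; beyond the scatter)). Naphthalen-2-yl and 2-chlorophenyl, though different, remain within the scatter of each other, so the position tolerates some aryl variation, but not every aryl group. Nothing available explains the weaker inhibition. Still open, from the compounds shown here alone, is whether the methoxy group itself or its place on the ring sets this step, and whether an amine or a carboxylic acid there would give a different number.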